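Swapping acetyl for dimethylamino on a weakly cytotoxic pyrazole series

The compounds below may be only part of what the source reports. "The series", "measured", "known", "first", "only" and "open" are said of these compounds alone.

Measured compounds:
compound 1, `COc1cc(C)cc(-c2c(-c3ccnc(-c4ccc(C(C)=O)cc4)c3)cnn2CC#N)c1`: 91%
compound 2, `COc1cc(C)cc(-c2nn(CC#N)cc2-c2ccc(-c3cccc(C(C)=O)c3)nc2)c1`: 91%
compound 3, `Cc1cc(O)cc(-c2nn(CC#N)cc2-c2ccnc(-c3ccc(Oc4ccccc4)cc3)c2)c1`: 96%

In a functional assay on NCI/ADR-RES cells (Homo sapiens) for cytotoxicity, read by sulforhodamine B assay, with a stated time of 48 h, tested at 0.01 uM (a higher number here means a weaker effect of the compound at the concentration tested, a lower number a stronger effect), compound 1 gives 91%. Compound 2 sits level with it at the digits shown, and the two together form the lowest pair of the three numbers. Compound 3 gives the highest number, but its gap to compound 1 lies within the usual scatter, so none of the three can be called stronger or weaker than another. All three leave cell growth largely untouched at this low concentration.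

Compound 4, `COc1cc(C)cc(-c2c(-c3ccnc(-c4ccc(N(C)C)cc4)c3)cnn2CC#N)c1`, has not yet been measured. It differs from compound 1 in one place: dimethylamino in place of acetyl on an aromatic carbon. Going by the values given here, no pair of measured compounds shows this change, so there is no measured step to lean on. The expectation is that the step from compound 1 to compound 4 stays within the scatter, with no clear direction, a number 1 percentage points higher from compound 1 to compound 4 (within the scatter). Compound 4 is therefore estimated at 92%, in a range from 80% to 102%.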

Compound 4, a percentage reported as activity, at one concentration (the size of the read-out at that concentration, not a potency): 80%
For compound 4 the middle estimate is 12 percentage points above the measured one, within the range that was stated.
By their numbers in this assay, from the lowest: compound 4; then compounds 1, 2 and 3 (each within the scatter of the next).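

In this assay, replacing 4-acetylphenyl with 4-(dimethylamino)phenyl gives a number 11 percentage points lower from compound 1 to compound 4 (beyond the scatter), a modest step but the only one here that can be read beyond the scatter. It shows that the position on the aromatic carbon para to a large group responds to the group placed there, even though the entering and leaving groups have the same heavy-atom count and each carries one hydrogen-bond acceptor. Nothing available explains why the number falls with this change.

Going by these compounds, it remains open whether another group at this position, such as diethylamino or a carboxylic acid, would lower the number further, and whether the same swap on compound 2 would give a similar step. With a read-out at one concentration, the step also says nothing about potency.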